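A few compounds are considered here, and "the series" means these few. Any claim that something is new, unique, unknown or untested is made for them only; others in the source may bear on it.

Compound 2 `COC(=O)c1ccc(C2(CNC(=O)Nc3c(C(C)C)cccc3C(C)C)CCCC2)cc1` has been measured in an assay on microsomes for inhibition of acyl-CoA:cholesterol acyltransferase (Oryctolagus cuniculus) (a higher number here means a weaker inhibitor, a lower number a stronger inhibitor), where compound 2 gives 360 nM. Of the two numbers obtained so far this is the highest, so compound 2 is the weaker of the two inhibitors. Within the data shown here, the only other measured compound is compound 1 `Cc1cccc(C2(CNC(=O)Nc3c(C(C)C)cccc3C(C)C)CCCC2)c1`; in this assay compound 1 gives 15 nM. Among the measured compounds shown here, the two differ in one place, and the step between them, a 24-fold higher number from compound 1 to compound 2 (1.38 log units; beyond the scatter), is the only measured step available.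

Compound 3 `CC(C)c1cccc(C(C)C)c1NC(=O)NCC1(c2ccc(C(=O)O)cc2)CCCC1` differs from compound 2 in one place: hydrogen in place of methyl on an oxygen next to a carbonyl group. For the measured compounds named here, no measured step mirrors this particular change. Going by the values given here, the single step, a 24-fold higher number from compound 1 to compound 2 (1.38 log units; beyond the scatter), concerns a different replacement on the same saturated ring carbon, and shows only that changes in this part of the molecule can move the number a great deal. Among the compounds with values here, with no direct precedent, the expectation is cautious: compound 3 is expected to show a moderately higher number than compound 2, a step of a 4.2-fold higher number from compound 2 to compound 3 (0.62 log units; beyond the scatter), with the outcome uncertain in both size and direction. Compound 3 is therefore estimated at 1500 nM, within a range from 300 nM to 8000 nM.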

Compound 3, half-maximal inhibitory concentration: 3100 nM
The estimate for compound 3 lay 2.1-fold (0.32 log units) below the measured number, and the stated range covers the measured number.
By their numbers in this assay, from the lowest: compound 1; then compound 2; then compound 3.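

Taking only the methyl off the ester of compound 2, so that 4-(methoxycarbonyl)phenyl becomes 4-carboxyphenyl, raises the number further in this assay (an 8.6-fold higher number from compound 2 to compound 3 (0.94 log units; beyond the scatter)). Among these compounds, the earlier pair showed only one whole group on the saturated ring carbon replaced by another, whereas this result shows that a change of a single methyl within that group also moves the number beyond the scatter. Measured against the 3-methylphenyl group of compound 1, the 4-carboxyphenyl group gives the largest step seen so far (a 210-fold higher number from compound 1 to compound 3 (2.32 log units; beyond the scatter)), though nothing available here explains this step or the one from the ester to the acid.

In these compounds, the kind of group and its place on the phenyl ring change together, so the 3-methylphenyl group cannot be compared cleanly with a 3-carboxyphenyl or 4-methylphenyl group. Also open, going by these compounds, is how a primary amide, a hydroxymethyl group or an amine would read in place of the carboxylic acid, and whether a longer ester such as ethoxycarbonyl would stay close to methoxycarbonyl.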